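A few compounds are considered here, and "the series" means these few. Any claim that something is new, unique, unknown or untested is made for them only; others in the source may bear on it.

Measured compounds:
- Compound 1 `COc1ccc(Br)cc1S(=O)(=O)Nc1cccc2cccnc12`: 68500 nM
- Compound 2 `O=[N+]([O-])c1ccc(S(=O)(=O)Nc2cnc3ccccc3c2)cc1`: 31600 nM

In an assay for inhibition of beta-glucuronidase (Bos taurus), read by spectrophotometry, with a stated time of 30 min (on this read-out lower numbers stand for stronger inhibition and higher numbers for weaker inhibition), compound 2 gives 31600 nM, the lower of the two numbers recorded so far. Its nearest neighbour is compound 1, which in this assay gives 68500 nM, a gap that lies beyond the usual scatter of repeated measurements. No single-point comparison between the two measured compounds is available, since they differ in more than one place.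

Compound 3 `CCCc1ccc(S(=O)(=O)Nc2cnc3ccccc3c2)cc1` is the next member, not yet measured. It differs from compound 2 in one place: propyl in place of nitro on an aromatic carbon. For the measured compounds named here, no measured pair shows the effect of this kind of exchange, so the expectation rests only on the starting point. The step from compound 2 to compound 3 is expected to be small, likely no larger than the scatter, with a slight lean toward a lower number; this expectation is expressed as a 1.3-fold lower number from compound 2 to compound 3 (0.10 log units; within the scatter). For compound 3 the estimated value in this assay is 25000 nM, with a range from 8000 nM to 80000 nM.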

Compound 3, half-maximal inhibitory concentration: 27200 nM
Compound 3: middle estimate off by 1.1-fold (0.04 log units), on the low side; low and high end bracket the measured number.
By their numbers in this assay, from the lowest: compounds 3 and 2 (each within the scatter of the next); then compound 1.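

In this assay, for the compounds shown here, the exchange of nitro for propyl on this aromatic carbon, para to a large group, gives a 1.2-fold lower number from compound 2 to compound 3 (0.07 log units; within the scatter), the first comparison here that differs in one place only. The step stays within the scatter, so at this position the assay does not tell the two groups apart, even though nitro carries hydrogen-bond acceptors and propyl carries none. Nothing at hand bears on why these two groups read alike.

The compounds shown leave open whether an amine, a carboxylic acid or a longer chain at this same position would move the number beyond the scatter. They also leave open whether a group on this carbon matters at all, as a compound with hydrogen there is not among them.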